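Replacing a Terminal Methoxy with Methyl on the Chain

A few compounds are considered here, and "the series" means these few. Any claim that something is new, unique, unknown or untested is made for them only; others in the source may bear on it.

Compound 3 `COCCCO/N=C/c1c(N)ncnc1Oc1ccc2[nH]c(C)cc2c1F` gives 346 nM in a functional assay on HeLa cells (Homo sapiens) for antiproliferative activity (on this read-out higher numbers stand for weaker inhibition and lower numbers for stronger inhibition), the lowest of the three numbers shown. Compound 1 `Cc1cc2c(F)c(Oc3ncnc(N)c3/C=N/OCCCO)ccc2[nH]1` gives 362 nM in this assay, and the two sit within the scatter of each other, so no order between them can be read. Compound 2 `CO/N=C/c1c(N)ncnc1Oc1ccc2[nH]ccc2c1` gives 1870 nM in this assay, and its gap to compound 3 lies beyond the scatter.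

Compound 4 `CCCCO/N=C/c1c(N)ncnc1Oc1ccc2[nH]c(C)cc2c1F` differs from compound 3 in one place: methyl in place of methoxy on a saturated chain carbon, three bonds along the chain from an oxygen on an unsaturated carbon. Among the measured compounds shown here, the only measured step that alters the same chain is the one from compound 1 to compound 3, a 1.0-fold lower number from compound 1 to compound 3 (0.02 log units; within the scatter), in which methyl took the place of hydrogen on an oxygen on a saturated carbon and the number stayed within the scatter. For the measured compounds named here, no measured pair removes that oxygen outright, so the present change goes one bond further than anything already seen, with that single step as its precedent. On this basis no step beyond the scatter is expected, and the estimated step, a 1.2-fold higher number from compound 3 to compound 4 (0.06 log units; within the scatter), is within the scatter. Compound 4 is therefore expected to give 400 nM in this assay, with a range from 150 nM to 1100 nM.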

Compound 4, half-maximal inhibitory concentration: 607 nM
For compound 4 the middle estimate is 1.5-fold (0.18 log units) below the measured one; the range from low to high includes it.
By their numbers in this assay, from the lowest: compounds 3, 1 and 4 (each within the scatter of the next); then compound 2.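

On this chain the oxygen is not needed for a number in the same range: in this assay the exchange of 3-methoxypropyl for butyl gives a 1.8-fold higher number from compound 3 to compound 4 (0.24 log units; within the scatter) and so removes the oxygen outright, which the earlier step had left in place. Counted from the hydroxy end of the same chain, the step is a 1.7-fold higher number from compound 1 to compound 4 (0.22 log units; within the scatter) and also stays inside the scatter, so hydroxy, methoxy and methyl at this chain end cannot be put in any order on these numbers. Nothing at hand bears on what lies behind these numbers.

Going by these compounds, whether an amine or a carboxylic acid at this chain end, or a longer chain such as pentyl, would stay within the scatter of these three compounds remains open. Compound 2 differs from them in more than one place, so its distance from the group cannot be assigned to the chain or to any other single part of the structure.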